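Changing the aryl group where cytotoxicity readings hit a limit

The source may report more compounds than this note shows. Statements on the series, on what has been measured and on what is new or still open speak of the compounds shown alone.

Compound 1 `CC1(COc2ccc(-c3ccc(F)cc3)cn2)Cn2cc([N+](=O)[O-])nc2O1` and compound 2 `CC1(COc2ccc(-c3ccc(C(F)(F)F)cc3)cn2)Cn2cc([N+](=O)[O-])nc2O1` share one core, and both were tested in an ADME assay on MRC5 cells (Homo sapiens) for cytotoxicity, read by fluorescence, with a stated time of 72 h; a lower number here means a stronger inhibitor, a higher number a weaker inhibitor. Compound 1 gives > 64000 nM, which is a limit of the assay and not a number. Compound 2 gives > 64000 nM, which is also a limit and not a number. Compound 2 therefore has no exact place on the scale, and nothing shown ranks it against compound 1.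

Compound 3 `CC1(COc2ccc(-c3ccc(F)cn3)cn2)Cn2cc([N+](=O)[O-])nc2O1` carries 5-fluoropyridin-2-yl in place of 4-(trifluoromethyl)phenyl on an aromatic carbon of the shared core (5-fluoropyridin-2-yl in place of 4-(trifluoromethyl)phenyl on an aromatic carbon). For the measured compounds named here, the only measured step is a step that the two limits leave unreadable from compound 1 to compound 2, a swap of fluoro for trifluoromethyl, so no measured size carries over to this new change. Going by the values given here, the one guide is that compound 1 and compound 2 both sit at the same bound: the limit of > 64000 nM in this assay, at which 2 of the 2 values shown sit. No step beyond the usual scatter is therefore expected in this assay, and a reading at the same limit is the likeliest result. The expected change is an at least 1.0-fold lower number from compound 2 to compound 3 (0.02 log units; that floor lies within the scatter). For compound 3 the estimate is 60000 nM, with an expected range from 28000 nM to 64000 nM.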

Compound 3, half-maximal inhibitory concentration: > 64000 nM
Compound 3 ended at the assay's limit; the forecaster's own chance of this, stated with the estimate: 80%; middle value at least 1.0-fold (0.02 log units) away from the limit.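

In this assay compound 3 gives > 64000 nM, which is a limit of the assay and not a number. No step among compound 1, compound 2 and compound 3 can be read, because all three sit at one bound: the limit of > 64000 nM in this assay, at which 3 of the 3 values shown sit.

As far as these compounds go, whether these aryl groups differ at all in cytotoxicity, and at what concentration each compound would reach half-maximal inhibition, stays open.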